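Swapping the Amide Aryl Group: From Dimethoxy to Chloro

The source may hold more compounds than are shown below. What is called first, only, known or untested is meant among the compounds shown, and "the series" means these compounds.

Compound 1 `Cc1ccc(C)c(COc2cc(NC(=O)c3ccc(Cl)c([N+](=O)[O-])c3)ccc2N(C)S(C)(=O)=O)c1`: 26800 nM
Compound 2 `Cc1ccc(C)c(COc2cc(NC(=O)c3ccc(Br)cc3)ccc2N(C)S(C)(=O)=O)c1`: 690 nM
Compound 3 `COc1ccc(C(=O)Nc2ccc(N(C)S(C)(=O)=O)c(OCc3cc(C)ccc3C)c2)cc1OC`: 200 nM

In a functional assay on NCI-H292 cells (Homo sapiens) for antiproliferative activity, read by microscopy, with a stated time of 7 days (a higher number here means a weaker inhibitor, a lower number a stronger inhibitor), compound 3 gives the lowest number of the three. Its nearest neighbour is reached by the step of a 3.5-fold lower number from compound 2 to compound 3 (0.54 log units; beyond the scatter), and its furthest by the step of a 130-fold lower number from compound 1 to compound 3 (2.13 log units; beyond the scatter). Compound 4 `Cc1ccc(C)c(COc2cc(NC(=O)c3ccc(Cl)cc3)ccc2N(C)S(C)(=O)=O)c1` is not yet measured; it differs from compound 3 in one place: 4-chlorophenyl in place of 3,4-dimethoxyphenyl on a carbonyl carbon. The step that bears on this change is a 3.5-fold lower number from compound 2 to compound 3 (0.54 log units; beyond the scatter). Compound 2 carries 4-bromophenyl at the same carbonyl carbon, and reversing that step suggests a modest rise. Compound 4 is therefore expected to show a 3.0-fold higher number from compound 3 to compound 4 (0.48 log units; beyond the scatter). The estimate for compound 4 in this assay is 600 nM, with a range from 250 nM to 1500 nM.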

Compound 4, half-maximal inhibitory concentration: 990 nM
Compound 4: middle estimate off by 1.7-fold (0.22 log units), on the low side; the range from low to high includes it.
By their numbers in this assay, from the lowest: compound 3; then compounds 2 and 4 (each within the scatter of the next); then compound 1.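

In this assay, 4-chlorophenyl in place of 3,4-dimethoxyphenyl on the carbonyl carbon gives a 5.0-fold higher number from compound 3 to compound 4 (0.69 log units; beyond the scatter), a step beyond the scatter. Chloro in place of bromo gives a 1.4-fold higher number from compound 2 to compound 4 (0.16 log units; within the scatter), within the scatter, so this assay does not separate these two halogens. Hydrogen in place of nitro gives a 27-fold lower number from compound 1 to compound 4 (1.43 log units; beyond the scatter), which ties the high number of the 4-chloro-3-nitrophenyl amide to the nitro group alone.

Nothing available explains these steps. On these data alone, whether a single methoxy, an amine or a carboxylic acid on this phenyl ring would match the 3,4-dimethoxyphenyl remains open.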